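Chain extension on the oxa-bridged acid series

The source may hold more compounds than are shown below. What is called first, only, known or untested is meant among the compounds shown, and "the series" means these compounds.

Measured so far:
compound 1, `O=C(O)CCC/C=C\C[C@H]1C(=O)C[C@@H](O)[C@@H]1/C=C/[C@@H](O)COc1ccccc1` — 16 nM
compound 2, `O=C(O)CCC[C@@H]1CC[C@@H]2[C@@H](/C=C/[C@@H](O)COc3ccccc3)[C@H](O)C[C@@H]2O1` — 4.1 nM
compound 3, `O=C(O)CCC1=CC[C@@H]2[C@@H](/C=C/[C@@H](O)COc3ccccc3)[C@H](O)C[C@@H]2OC1` — 530 nM

In a functional assay on CHO cells for agonist activity at prostaglandin F2-alpha receptor (Homo sapiens), read by fluorescence and calcium flux (a higher number here means that more compound is needed for the effect, a lower number that less compound is needed), compound 3 gives 530 nM, the highest number of the three. Compound 1 gives 16 nM and compound 2 gives 4.1 nM, both well below compound 3 and each separated from it by more than the scatter. For the measured compounds named here, the three compounds differ in more than one place, so no single step between them can be read.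

Compound 4, `O=C(O)CCCCC1=CC[C@@H]2[C@@H](/C=C/[C@@H](O)COc3ccccc3)[C@H](O)C[C@@H]2OC1`, is not yet measured. It differs from compound 3 in one place: 2-carboxyethyl in place of carboxy on a saturated chain carbon, two bonds along the chain from a double-bonded ring carbon. The acid chain of compound 4 thereby approaches the length found in compound 1 and compound 2, both of which give lower numbers than compound 3. On that basis a drop beyond the scatter is expected: the step from compound 3 to compound 4 is estimated at a 13-fold lower number from compound 3 to compound 4 (1.12 log units; beyond the scatter), because compound 1 at 16 nM and compound 2 at 4.1 nM carry longer acid chains than compound 3. For compound 4 in this assay the expected value is 40 nM, with a range from 6 nM to 250 nM.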

Compound 4, half-maximal effective concentration: 73 nM
Compound 4: middle estimate off by 1.8-fold (0.26 log units), on the low side; the range from low to high includes it.
By their numbers in this assay, from the lowest: compound 2; then compound 1; then compound 4; then compound 3.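

In this assay, the saturated chain carbon two bonds along the chain from a double-bonded ring carbon proves sensitive to what it carries: 2-carboxyethyl in place of carboxy gives a 7.3-fold lower number from compound 3 to compound 4 (0.86 log units; beyond the scatter). For the compounds shown here, this is the first single-place step, and it shows that extending the acid chain at this position, with the carboxylic acid kept at its end, lowers the number by more than the scatter. Nothing at hand accounts for the size of this step.

Steps from compound 4 to compound 1 or compound 2 cannot be read, as those pairs differ in more than one place. On these data alone, whether a still longer chain ending in a carboxylic acid lowers the number further, and whether an amide at the chain end retains the effect, stays open.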